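This account rests on a few compounds, and the source may have more. Where it says the series, first, only, none or still open, it means among the compounds named here.

Measured so far:
compound 1 `COc1ccc(Cn2c(CCc3ccccc3)nnc2[C@H](NC(=O)C(C)(C)N)c2c[nH]c3ccccc23)c(OC)c1` — in a functional assay on CHO cells for antagonist activity at growth hormone secretagogue receptor type 1 (Homo sapiens) (on this read-out lower numbers stand for stronger inhibition and higher numbers for weaker inhibition), compound 1 gives 17 nM
compound 2 `COc1ccc(Cn2c(CCc3c[nH]c4ccccc34)nnc2[C@H](NC(=O)c2ccccn2)c2c[nH]c3ccccc23)c(OC)c1` — in this assay compound 2 gives 19 nM

Compound 2 carries the higher of the two numbers in this assay, but its nearest neighbour, compound 1, sits within the scatter of it, so the two are not distinguishable on these data. Among the compounds with values here, no single-point step between measured compounds is available in this set; compound 1 and compound 2 differ at two places at once, so their values show only that both sit in the same range.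

Compound 3 `COc1ccc(Cn2c(CCc3ccccc3)nnc2[C@H](NC(=O)c2ccccn2)c2c[nH]c3ccccc23)c(OC)c1` is the next member and has not been measured in this assay. It differs from compound 2 in one place: phenyl in place of 1H-indol-3-yl on a saturated chain carbon, two bonds along the chain from an aromatic carbon. The amide part of compound 2 is kept. Compound 1 already carries the same phenethyl chain with a different amide and gives a number in the same band as compound 2, so the change is expected to move the read-out little, if at all. The step from compound 2 to compound 3 is estimated at a 1.1-fold higher number from compound 2 to compound 3 (0.02 log units; within the scatter), with no clear direction beyond the scatter. For compound 3 the estimate in this assay is 20 nM, within a range from 8 nM to 50 nM.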

Compound 3, antagonist equilibrium constant: 25 nM
For compound 3 the middle estimate is 1.3-fold (0.10 log units) below the measured one, and the stated range covers the measured number.
By their numbers in this assay, from the lowest: compounds 1, 2 and 3 (each within the scatter of the next).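

In this assay, within the data shown here, phenyl in place of 1H-indol-3-yl on a saturated chain carbon, two bonds along the chain from an aromatic carbon, gives a 1.3-fold higher number from compound 2 to compound 3 (0.12 log units; within the scatter), the first reading at this position with everything else held constant. Losing the five-membered aromatic ring and the hydrogen-bond donor of the 1H-indol-3-yl group therefore leaves no readable mark on the number, and the 2-(1H-indol-3-yl)ethyl and phenethyl chains cannot be told apart here, at least with the pyridin-2-yl amide in place. The amide position can now also be read alone: pyridin-2-yl in place of 1-amino-1-methylethyl on a carbonyl carbon gives a 1.5-fold higher number from compound 1 to compound 3 (0.17 log units; within the scatter), so these two groups cannot be told apart either on the phenethyl chain, and no measurement at hand bears on why the series is so flat at both positions.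

On these data alone, all three compounds keep an aromatic ring at the end of a two-carbon chain, so it remains open whether a longer chain, or a simple alkyl group such as methyl, would hold the number in this band. As far as these compounds go, it is equally open whether an amine or a carboxylic acid on the phenyl ring would move the read-out beyond the scatter.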